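A few compounds are considered here, and "the series" means these few. Any claim that something is new, unique, unknown or untested is made for them only; others in the source may bear on it.

The series comprises compound 1 `Cc1ccc(S(=O)(=O)Nc2ccc(-c3cc(-c4ccc([N+](=O)[O-])cc4)n(C(N)=S)n3)cc2)cc1`, compound 2 `Cc1ccc(S(=O)(=O)Nc2ccc(C(=O)/C=C/c3ccccc3)cc2)cc1`, compound 3 `Cc1ccc(S(=O)(=O)Nc2ccc(-c3cc(-c4ccc([N+](=O)[O-])cc4)[nH]c(=O)n3)cc2)cc1` and the as yet unmeasured compound 4 `Cc1ccc(S(=O)(=O)Nc2ccc(C(=O)/C=C/c3ccc([N+](=O)[O-])cc3)cc2)cc1`. In a functional assay on HepG2 cells (Homo sapiens) for cytotoxicity, read by sulforhodamine B assay, with a stated time of 48 h (a higher number here means a weaker inhibitor, a lower number a stronger inhibitor), compound 1 is recorded as "not active" (no number reported). In this assay compound 2 is likewise recorded as "not active" (no number reported), so it stands without a single number, one of two entries of that kind in the set. In this assay compound 3 gives 46300 nM, the only numerical result among the measured compounds. Compound 4 differs from compound 2 in one place: nitro in place of hydrogen on an aromatic carbon. Within the data shown here, no measured pair shows this same change, so no step can be read directly. Both compound 1 and compound 3 carry a 4-nitrophenyl, and compound 3 with its result of 46300 nM is weak, so a step from compound 2 to compound 4 is expected to be small or none beyond the scatter, with compound 4 remaining weak. In this assay compound 4 is estimated at 60000 nM, within a range from 20000 nM to 200000 nM, and a result reported only as inactive remains quite possible.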

Compound 4, half-maximal inhibitory concentration: 26000 nM
Beside the measured number, compound 4's estimate is 2.3-fold (0.36 log units) above it, and the stated range covers the measured number.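

No step can be read between compound 2 and compound 4 in this assay: compound 2 stands without a single number, while compound 4 gives 26000 nM. How far nitro in place of hydrogen shifts the result stays open, and no evidence at hand explains the result.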